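A few compounds are considered here, and "the series" means these few. Any claim that something is new, unique, unknown or untested is made for them only; others in the source may bear on it.

The measured compounds are three. Compound 1, `Nc1ncn(C/C=C2\OC(=O)C(OCc3ccccc3)=C2OCc2ccccc2)c(=O)n1`, gives 2720 nM in a functional assay on HepG2 cells (Homo sapiens) for inhibition, read by MTT assay, with a stated time of 72 h; on this read-out higher numbers stand for weaker inhibition and lower numbers for stronger inhibition. Compound 2, `O=C1O/C(=C\Cn2c(=O)[nH]c(=O)[nH]c2=O)C(OCc2ccccc2)=C1OCc1ccccc1`, gives 44800 nM in this assay. Compound 3, `O=C1O[C@H]([C@@H](O)Cn2c(=O)[nH]c(=O)[nH]c2=O)C(OCc2ccccc2)=C1OCc1ccccc1`, reaches only the limit of this assay, > 100000 nM, which is a limit and not a number.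

Compounds 1 and 2 share one core, and the step between them is a 16-fold lower number from compound 2 to compound 1 (1.22 log units; beyond the scatter). The change behind it is a group of 8 heavy atoms (3 carbon, 4 nitrogen, 1 oxygen; one six-membered aromatic ring with 3 hetero atoms) in place of a group of 9 heavy atoms (3 carbon, 3 nitrogen, 3 oxygen; one six-membered aromatic ring with 3 hetero atoms), on a saturated chain carbon bound to a double-bonded chain carbon. Compound 3 has a different core, with a hydroxyl on the chain and a saturated ring carbon in place of the exocyclic double bond; how its core differs from that of compound 2 is not broken down here. Compound 3 sits at the limit of > 100000 nM in this assay, at which 1 of the 3 values shown sits.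

Compound 4, `Nc1ncn(C[C@H](O)[C@H]2OC(=O)C(OCc3ccccc3)=C2OCc2ccccc2)c(=O)n1`, is not yet measured. It differs from compound 3 by a group of 8 heavy atoms (3 carbon, 4 nitrogen, 1 oxygen; one six-membered aromatic ring with 3 hetero atoms) in place of a group of 9 heavy atoms (3 carbon, 3 nitrogen, 3 oxygen; one six-membered aromatic ring with 3 hetero atoms), on a saturated chain carbon, two bonds along the chain from an oxygen on a saturated carbon and a saturated ring carbon. This is the same kind of change as that from compound 2 to compound 1, but not the same: there it sat on a saturated chain carbon bound to a double-bonded chain carbon, here it sits on a saturated chain carbon, two bonds along the chain from an oxygen on a saturated carbon and a saturated ring carbon.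

A step of an at least 3.3-fold lower number from compound 3 to compound 4 (0.52 log units; beyond the scatter) is expected, resting on the size of a 16-fold lower number from compound 2 to compound 1 (1.22 log units; beyond the scatter) applied to a starting point that is itself only a limit. Compound 4 is therefore estimated at about 30000 nM, between 8000 nM and 120000 nM, with a real chance that this assay again reports only a limit.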

Compound 4, half-maximal inhibitory concentration: > 100000 nM
Compound 4: only a limit was reported; the forecaster's own chance of this, stated with the estimate: 35%; middle value at least 3.3-fold (0.52 log units) away from the limit.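

Compound 3 and compound 4 both reach only a limit in this assay, not a number, so no step can be read between them: the limit of > 100000 nM in this assay, at which 2 of the 4 values shown sit.

The compounds shown leave open whether the exchange of groups that separates compound 2 from compound 1 changes the read-out at all on the core shared by compound 3 and compound 4.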